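Urea aryl swap: from compound 1 to compound 3

A few compounds are considered here, and "the series" means these few. Any claim that something is new, unique, unknown or untested is made for them only; others in the source may bear on it.

Among the measured compounds shown here, compound 1 `COc1cc(Cl)cc(-c2nn(-c3cccc(NC(=O)Nc4cccc(C(F)(F)F)c4)c3)cc2-c2ccncc2)c1` is one of two compounds so far measured in a functional assay on SNB-75 cells (Homo sapiens) for inhibition, read by sulforhodamine B assay, with a stated time of 48 h, tested at 0.01 uM; a higher number here means a weaker effect of the compound at the concentration tested, a lower number a stronger effect. Compound 1 gives 83%, the lower of the two numbers recorded. For the measured compounds named here, compound 2 `O=C(Nc1cccc(-n2cc(-c3ccncc3)c(-c3cc(O)cc(Cl)c3)n2)c1)Nc1ccc(Cl)c(Cl)c1` gives 94%, a number higher than that of compound 1 by more than the usual scatter; compound 2 differs from compound 1 in more than one place, so no single step connects them. Compound 3 `COc1cc(Cl)cc(-c2nn(-c3cccc(NC(=O)Nc4ccc(Cl)c(Cl)c4)c3)cc2-c2ccncc2)c1` is not yet measured. It differs from compound 1 in one place: 3,4-dichlorophenyl in place of 3-(trifluoromethyl)phenyl on an amide-type nitrogen. Going by the values given here, no measured pair shows this change on its own. Among the compounds with values here, since the group that enters is the one carried by compound 2, whose 94% is the higher number, a modest shift toward a weaker effect is expected, a number 7 percentage points higher from compound 1 to compound 3 (within the scatter), though it may not exceed the scatter. The estimate for compound 3 is 90%, with a range from 78% to 100%.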

Compound 3, a percentage reported as activity, at one concentration (the size of the read-out at that concentration, not a potency): 88%
Compound 3: the middle estimate sits 2 percentage points above what was measured, within the range that was stated.
By their numbers in this assay, from the lowest: compounds 1, 3 and 2 (each within the scatter of the next, the first and the last beyond it).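

In this assay, 3,4-dichlorophenyl in place of 3-(trifluoromethyl)phenyl on an amide-type nitrogen gives a number 5 percentage points higher from compound 1 to compound 3 (within the scatter) and so does not separate these two aryl groups at this position. Methyl in place of hydrogen on an oxygen on an aromatic ring gives a number 6 percentage points lower from compound 2 to compound 3 (within the scatter) and so does not separate the two compounds at that place either, although compound 1 and compound 2 lie beyond the scatter of each other and differ in both places. No measurement on these compounds bears on why the numbers fall as they do.

Still open, as far as these compounds go, is whether an unsubstituted phenyl, a pyridyl, or an aryl group carrying an amine or a carboxylic acid on the amide-type nitrogen would move the read-out beyond the scatter. Also open, from the compounds shown here alone, is whether an ethoxy group in place of the methoxy group would do so.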